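Chloro added to the 4-(trifluoromethyl)phenyl analogue

The source may report more compounds than this note shows. Statements on the series, on what has been measured and on what is new or still open speak of the compounds shown alone.

Three acrylic acids sharing one core have numbers in a functional assay on MCF7 cells (Homo sapiens) for inhibition; on this read-out lower numbers stand for stronger inhibition and higher numbers for weaker inhibition. Compound 1 `CC/C(=C(/c1ccc(/C=C/C(=O)O)cc1)c1cc2ccccc2[nH]1)c1cccc(C(F)(F)F)c1` gives 325 nM; compound 2 `CC/C(=C(/c1ccc(/C=C/C(=O)O)cc1)c1cc2ccccc2[nH]1)c1ccc(Cl)cc1` gives 343 nM; compound 3 `CC/C(=C(/c1ccc(/C=C/C(=O)O)cc1)c1cc2ccccc2[nH]1)c1ccc(C(F)(F)F)cc1` gives 139 nM, the lowest of the three, with a 2.3-fold lower number from compound 1 to compound 3 (0.37 log units; beyond the scatter) and a 2.5-fold lower number from compound 2 to compound 3 (0.39 log units; beyond the scatter), both beyond the scatter, while a 1.1-fold higher number from compound 1 to compound 2 (0.02 log units; within the scatter) stays within it. Compound 4 `CC/C(=C(/c1ccc(/C=C/C(=O)O)cc1)c1cc2ccccc2[nH]1)c1ccc(C(F)(F)F)cc1Cl` carries chloro in place of hydrogen on an aromatic carbon, so the aryl reads 2-chloro-4-(trifluoromethyl)phenyl. Within the data shown here, no measured step adds a group to this ring while keeping the trifluoromethyl; the steps from compound 2 to compound 3 and from compound 1 to compound 3 show only that altering this ring moves this assay modestly. Since compound 3 keeps its trifluoromethyl, the expected step to compound 4 is a 1.2-fold lower number from compound 3 to compound 4 (0.06 log units; within the scatter), not clearly beyond the scatter. Compound 4 is estimated at 120 nM, between 50 nM and 300 nM.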

Compound 4, half-maximal inhibitory concentration: 27 nM
Compound 4: middle estimate off by 4.4-fold (0.65 log units), on the high side; measured number outside the range, below it.
By their numbers in this assay, from the lowest: compound 4; then compound 3; then compounds 1 and 2 (each within the scatter of the next).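

In this assay, chloro in place of hydrogen on the aromatic carbon ortho to a large group gives a 5.1-fold lower number from compound 3 to compound 4 (0.71 log units; beyond the scatter) here, so this position moves the number further than either earlier change on this ring did. Among these compounds, the whole aryl change gives a 13-fold lower number from compound 2 to compound 4 (1.10 log units; beyond the scatter) and a 12-fold lower number from compound 1 to compound 4 (1.08 log units; beyond the scatter) as the first large steps. Nothing measured here accounts for the size of the step.

As far as these compounds go, whether a fluoro, methyl or methoxy group on this carbon would act like chloro stays open. So does whether chloro gives a similar step on the 4-chlorophenyl or 3-(trifluoromethyl)phenyl analogues.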